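The source may report more compounds than this note shows. Statements on the series, on what has been measured and on what is new or still open speak of the compounds shown alone.

Of the compounds shown here, three built on one shared core have been tested in a functional assay on A-375 cells (Homo sapiens) for cytotoxicity, read by MTT assay; on this read-out higher numbers stand for weaker inhibition and lower numbers for stronger inhibition. Compound 1 `O=C(NCCCNc1nccc(-c2c(-c3cccc(F)c3)nc3sccn23)n1)c1ccc(Cl)cc1` gives 13700 nM. Compound 2 `O=S(=O)(NCCNc1nccc(-c2c(-c3cccc(F)c3)nc3sccn23)n1)c1ccc(F)cc1` gives 9450 nM, and compound 3 `O=S(=O)(NCCNc1nccc(-c2c(-c3cccc(F)c3)nc3sccn23)n1)c1ccc(Cl)cc1` gives 18600 nM. On these numbers compound 3 cannot be separated from either neighbour: a 1.4-fold higher number from compound 1 to compound 3 (0.13 log units; within the scatter), and a 2.0-fold higher number from compound 2 to compound 3 (0.29 log units; within the scatter). Compound 4 `O=S(=O)(NCCNc1nccc(-c2c(-c3cccc(F)c3)nc3sccn23)n1)c1ccc(C(F)(F)F)cc1` has not yet been measured. It differs from compound 3 in one place: trifluoromethyl in place of chloro on an aromatic carbon. Among the measured steps, only the one from compound 2 to compound 3 changes a group on an aromatic carbon of that same six-membered ring of carbon only, and that step stayed within the scatter. The other two steps, a 1.4-fold lower number from compound 1 to compound 2 (0.16 log units; within the scatter) and a 1.4-fold higher number from compound 1 to compound 3 (0.13 log units; within the scatter), swap a whole linker and also stayed within the scatter. No step beyond the scatter is therefore expected in this assay in either direction. Compound 4 is expected to give about 18000 nM, within a range from 8000 nM to 40000 nM. The expected step is a 1.0-fold lower number from compound 3 to compound 4 (0.01 log units; within the scatter).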

Compound 4, half-maximal inhibitory concentration: 7440 nM
Beside the measured number, compound 4's estimate is 2.4-fold (0.38 log units) above it; measured number outside the range, below it.
By their numbers in this assay, from the lowest: compounds 4, 2, 1 and 3 (each within the scatter of the next, the first and the last beyond it).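

Swapping chloro for trifluoromethyl at this place on the ring gives the first step beyond the scatter in this assay, a 2.5-fold lower number from compound 3 to compound 4 (0.40 log units; beyond the scatter), so the group para to a large group can shift the number, if only modestly. The step of a 1.3-fold lower number from compound 2 to compound 4 (0.10 log units; within the scatter) stays within the scatter, so fluoro and trifluoromethyl cannot be told apart here, even though trifluoromethyl brings more heavy atoms, and only the chloro and trifluoromethyl pair is separated. Nothing shown bears on the cause of the step beyond the scatter.

The compounds shown leave open how a methoxy group or an amine would read at this place on the ring. They also leave open whether trifluoromethyl would give a similar step on the amide linker of compound 1.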